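The source may hold more compounds than are shown below. What is called first, only, known or untested is meant among the compounds shown, and "the series" means these compounds.

Compound 1 `O=C(N/N=C/c1ccc(-c2ccc(F)cc2)o1)c1ccccc1O` and compound 2 `O=C(N/N=C/c1ccc(Cl)cc1)c1ccc(-c2ccccc2F)o1` were both examined in a functional assay on HL-60 cells (Homo sapiens) for inhibition, read by MTT assay, with a stated time of 48 h, tested at 10 uM; a lower number here means less inhibition of growth, a higher number more inhibition of growth at the concentration tested. Compound 1 gives -2.08%, and compound 2 gives 6.49% in this assay. Compound 2 thus holds the higher of the two numbers, though its gap to compound 1 lies within the scatter, so the two cannot be ranked. Compound 3 `O=C(N/N=C/c1cccc(Br)c1)c1ccc(-c2ccccc2F)o1` is the next member. Compound 3 differs from compound 2 by 3-bromophenyl in place of 4-chlorophenyl on a carbon with a double bond to nitrogen. Among the measured compounds shown here, no measured step of this kind exists to draw on, so the step of a number 0.5 percentage points lower from compound 2 to compound 3 (within the scatter) is expected to stay within the scatter, in no clear direction. Compound 3 is estimated to give 6%, in the range -8% to 20%, in this assay.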

Compound 3, percent growth inhibition at one concentration: 27.7%
For compound 3 the middle estimate is 21.7 percentage points below the measured one, and the stated range ends below it.
By their numbers in this assay, from the lowest: compounds 1 and 2 (each within the scatter of the next); then compound 3.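

In this assay, 3-bromophenyl in place of 4-chlorophenyl on a carbon with a double bond to nitrogen gives a number 21.2 percentage points higher from compound 2 to compound 3 (beyond the scatter), the only step shown here and one that shows this position is sensitive to the group it carries. The halogen and its place on the phenyl ring change together in this step, so neither can be credited alone. Nothing measured here explains the step. Left open is whether 3-chlorophenyl or 4-bromophenyl would separate those two changes. Also open, from the compounds shown here alone, is how an amine or a carboxylic acid on that phenyl ring would read in this assay.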